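This account rests on a few compounds, and the source may have more. Where it says the series, first, only, none or still open, it means among the compounds named here.

Compound 1 `C=C1C[C@]23C[C@@]1(O)CC[C@H]2c1ccc(O)c(C)c1[C@@H]3Cn1cc(-c2ccccn2)nn1` gives > 20000 nM in a functional assay on HL-60 cells (Homo sapiens) for cytotoxicity, read by MTT assay, with a stated time of 4 days; a higher number here means a weaker inhibitor, a lower number a stronger inhibitor. Compound 2 `C=C1C[C@]23C[C@@]1(O)CC[C@H]2c1cc(Br)c(O)c(C)c1[C@@H]3Cn1cc(-c2ccc(OC)cc2)nn1` gives > 20000 nM in this assay. Compound 3 `C=C1C[C@]23C[C@@]1(O)CC[C@H]2c1cc(Br)c(O)c(C)c1[C@@H]3Cn1cc(-c2ccc(F)cc2)nn1` gives 6600 nM in this assay.

The value of compound 1 is a limit of the assay, not a number. The value of compound 2 is likewise a limit, not a number. Compound 2 therefore stands at the limit of > 20000 nM in this assay, at which 2 of the 3 values shown sit, the weak end of what the assay can report.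

The compound still to be measured is compound 4 `C=C1C[C@]23C[C@@]1(O)CC[C@H]2c1ccc(O)c(C)c1[C@@H]3Cn1cc(-c2ccc(OC)cc2)nn1`. It differs from compound 2 by hydrogen in place of bromo on an aromatic carbon. Within the data shown here, the only measured step, an at least 3.0-fold lower number from compound 2 to compound 3 (0.48 log units; beyond the scatter), concerns the group on the separate aromatic ring attached to the triazole, not the bromo on the core, so no measured step bears directly on this change. Compound 1, which also lacks the bromo but carries a different group on the triazole, offers no contrast, since its value is a limit.

With nothing measured to point the other way, the step of a number no higher from compound 2 to compound 4 (the limit leaves the size open) from compound 2 to compound 4 is expected to be none beyond the scatter. The estimate for compound 4 in this assay is 20000 nM, within a range of 8000 nM to 60000 nM, and it is expected that the assay may again report only a limit.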

Compound 4, half-maximal inhibitory concentration: > 20000 nM
Compound 4: a limit, no number; the forecaster's own chance of this, stated with the estimate: 70%; the middle value sits exactly at the limit.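

In this assay compound 4 gives > 20000 nM, which is a limit of the assay and not a number. Compound 1 and compound 2 also sit at a limit, so the steps from each of them to compound 4 cannot be read: the limit of > 20000 nM in this assay, at which 3 of the 4 values shown sit.

The compounds shown leave open whether hydrogen in place of bromo changes the value at all, as no pair differing only there has a number on both sides.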